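The source may report more compounds than this note shows. Statements on the series, on what has been measured and on what is new or still open speak of the compounds shown alone.

Working notes on the series. Compound 1 `Cc1cc(C)cc(-c2c(C)nn(-c3nc(-c4ccc(Cl)c(Cl)c4)c(SC(C)C)s3)c2C(=O)O)c1` and compound 2 `Cc1nn(-c2nc(-c3ccc(Cl)c(Cl)c3)c(SC(C)C)s2)c(C(=O)O)c1-c1ccc(C(F)(F)F)cc1` share one core and differ only in the aryl group on an aromatic carbon. In a functional assay on BJAB cells (Homo sapiens) for antiproliferative activity, with a stated time of 4 days (on this read-out higher numbers stand for an effect only at larger amounts of compound and lower numbers for an effect already at smaller amounts), compound 1 gives 2700 nM, and compound 2 gives 3500 nM. Among the compounds with values here, the single measured step is a 1.3-fold higher number from compound 1 to compound 2 (0.11 log units; within the scatter); the two numbers lie within the scatter of each other, so neither compound is set apart, and together they mark the whole range seen so far. Compound 3 `Cc1nn(-c2nc(-c3ccc(Cl)c(Cl)c3)c(SC(C)C)s2)c(C(=O)O)c1-c1ccccc1` is not yet measured. The change from compound 2 to compound 3 is hydrogen in place of trifluoromethyl on an aromatic carbon. Within the data shown here, the only step bearing on this position, a 1.3-fold higher number from compound 1 to compound 2 (0.11 log units; within the scatter), exchanged one aryl group for another without leaving the scatter, so in this assay no step beyond the scatter is expected here either. The step from compound 2 to compound 3 is expected to be no change at the digits printed from compound 2 to compound 3 (within the scatter). Compound 3 is estimated at 3500 nM, with a range from 1500 nM to 8500 nM.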

Compound 3, half-maximal effective concentration: 3000 nM
Beside the measured number, compound 3's estimate is 1.2-fold (0.07 log units) above it; measured number inside the range.
By their numbers in this assay, from the lowest: compounds 1, 3 and 2 (each within the scatter of the next).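

In this assay, the unsubstituted phenyl of compound 3 is not set apart from either substituted aryl group: hydrogen in place of trifluoromethyl gives (a 1.2-fold lower number from compound 2 to compound 3 (0.07 log units; within the scatter)) and phenyl in place of 3,5-dimethylphenyl gives (a 1.1-fold higher number from compound 1 to compound 3 (0.05 log units; within the scatter)). The earlier step only exchanged one substituted aryl group for another, whereas these two steps show that neither the trifluoromethyl of compound 2 nor the two methyl groups of compound 1 are required to keep the number at this level. No measurement shown here accounts for this flat response.

As far as these compounds go, whether an amine, a hydroxyl group or a longer chain on this phenyl would also stay within the scatter remains open. So does whether this flat response would persist with an amide in place of the carboxylic acid on the shared core.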